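Sulfonamide-amide series: affinity at the chemokine receptor

The source may hold more compounds than are shown below. What is called first, only, known or untested is meant among the compounds shown, and "the series" means these compounds.

Measured so far:
compound 1, `O=C(NCc1ccc(CNS(=O)(=O)c2ccccc2)cc1)c1cccc(F)c1`, gives 100 nM in an assay on MDA-MB-231 cells for binding affinity to C-X-C chemokine receptor type 4 (Homo sapiens), read by immunofluorescence and microscopy, with stated times of 10 min and 30 min; a higher number here means that more compound is needed for the effect, a lower number that less compound is needed
compound 2, `Cc1ccc(S(=O)(=O)NCc2ccc(CNC(=O)c3ccc([N+](=O)[O-])cc3)cc2)cc1`, gives 10 nM
compound 3, `COc1ccc(C(=O)NCc2ccc(CNS(=O)(=O)c3ccccc3)cc2)cc1`, gives 1000 nM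

Compound 2 stands lowest of the three numbers; compound 1 is nearest, a step above it, and compound 3 lies furthest away. Compound 4, `COc1cccc(C(=O)NCc2ccc(CNS(=O)(=O)c3ccc(C)cc3)cc2)c1`, differs from compound 2 in one place: 3-methoxyphenyl in place of 4-nitrophenyl on a carbonyl carbon. Going by the values given here, the only measured step at that carbonyl carbon is a 10-fold higher number from compound 1 to compound 3 (1.00 log units; beyond the scatter), where a methoxyphenyl entering in place of 3-fluorophenyl raised the number beyond the scatter. That step is the nearest guide, though it brought 4-methoxyphenyl rather than 3-methoxyphenyl and the leaving group was not 4-nitrophenyl. A rise of similar size is therefore expected for compound 4; the expected step is a 10-fold higher number from compound 2 to compound 4 (1.00 log units; beyond the scatter). Compound 4 is estimated at 100 nM, with a range from 30 nM to 400 nM.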

Compound 4, effective concentration (reported as EC, without a stated level of effect): 10 nM
Compound 4: middle estimate off by 10-fold (1.00 log units), on the high side, outside the stated range (below it).
By their numbers in this assay, from the lowest: compounds 2 and 4 (each within the scatter of the next); then compound 1; then compound 3.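

At this carbonyl carbon, 3-methoxyphenyl replaces 4-nitrophenyl with no change at the digits printed from compound 2 to compound 4 (within the scatter), so a methoxyphenyl group here does not by itself go with a higher number, and 4-nitrophenyl is not required for the low value. The rise in the other step, a 10-fold higher number from compound 1 to compound 3 (1.00 log units; beyond the scatter), does not carry over to this pair. Nothing at hand accounts for the difference between the two steps. Still open, as far as these compounds go, is whether the methoxy placement or the methyl group present in compound 2 and compound 4 but absent from compound 1 and compound 3 decides the outcome. Also open, from the compounds shown here alone, is how an amine or a carboxylic acid would read in place of 3-methoxyphenyl.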